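A Smaller Group on the Amide Carbonyl

The source may report more compounds than this note shows. Statements on the series, on what has been measured and on what is new or still open speak of the compounds shown alone.

Cell growth tests often give values that are hard to separate, and the two compounds measured here show why. In a functional assay on NCI-H1650 cells (Homo sapiens) for inhibition, read by sulforhodamine B assay, with a stated time of 3 days (a lower number here means a stronger inhibitor, a higher number a weaker inhibitor), compound 1 `O=C1Nc2ccc(F)cc2/C1=C\C(=O)c1ccc(C2CCCCC2)cc1` gives 2730 nM and compound 2 `COc1ccc(C(=O)Nc2ccc3c(c2)/C(=C/Nc2cccc(N4CCN(C)CC4)c2)C(=O)N3)cc1` gives 1870 nM as its reading. These two numbers lie within the usual scatter of each other, so compound 2 cannot be ranked apart from compound 1, even though their structures differ widely.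

Going by the values given here, compound 3 `CC(C)CC(=O)Nc1ccc2c(c1)/C(=C/Nc1cccc(N3CCN(C)CC3)c1)C(=O)N2` keeps most of compound 2 and carries isobutyl in place of 4-methoxyphenyl on a carbonyl carbon as its only change. Among the compounds with values here, the swap removes an aromatic ring, but no measured pair shows what such a swap does, so any forecast here is loose. The closest guide is compound 2 at 1870 nM in the same test. The expected result is a small move toward a weaker number, a 1.3-fold higher number from compound 2 to compound 3 (0.13 log units; within the scatter), which would stay within the scatter. For compound 3 the estimated value in this assay is 2500 nM, with an expected range from 700 nM to 8000 nM overall.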

Compound 3, half-maximal inhibitory concentration: 5870 nM
Compound 3: the middle estimate sits 2.3-fold (0.37 log units) below what was measured, within the range that was stated.
By their numbers in this assay, from the lowest: compounds 2 and 1 (each within the scatter of the next); then compound 3.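

On the carbonyl carbon whose other neighbour is the amide-type nitrogen, the choice of group shows up in this assay: isobutyl in place of 4-methoxyphenyl gives a 3.1-fold higher number from compound 2 to compound 3 (0.50 log units; beyond the scatter), a modest step, but one that lies beyond the scatter. Compounds 1 and 2 could not show this, since they differ in many places at once and their values lie within the scatter of each other, whereas this single change shows that the group at this position affects the reading. The change removes a six-membered aromatic ring and a hydrogen-bond acceptor and puts 4 heavy atoms where 8 stood, and no measurement here explains the step or says which of these differences matters.

The compounds shown leave open whether the ring itself or its methoxy group accounts for the lower number of compound 2, a question that a plain phenyl group on the same carbonyl carbon would help to settle. They also leave open how a saturated ring such as cyclohexyl, or a longer chain ending in an amine, would read at this position.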